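This account rests on a few compounds, and the source may have more. Where it says the series, first, only, none or still open, it means among the compounds named here.

Measured compounds:
- Compound 1, `CC1=C(/C=C/C(=O)/C=C/c2ccccc2)C(C)(C)CCC1O`: 12600 nM
- Compound 2, `CC1=C(/C=C/C(=O)/C=C/c2cccc(C(F)(F)F)c2)C(C)(C)CCC1O`: 2600 nM
- Compound 3, `CC1=C(/C=C/C(=O)/C=C/c2cccc(C#N)c2)C(C)(C)CCC1O`: "not determined" (no result reported)

These three share one core and differ only in the group on the outer aromatic ring. In a functional assay on PCa 2b cells (Homo sapiens) for cytotoxicity, read by MTT assay, with a stated time of 72 h (a lower number here means a stronger inhibitor, a higher number a weaker inhibitor), compound 1 gives 12600 nM, and compound 2 gives 2600 nM. Going by the values given here, the single measured step, a 4.8-fold lower number from compound 1 to compound 2 (0.69 log units; beyond the scatter), shows that putting a group on that ring at this position can lower the number. Among the compounds with values here, for compound 3 no number was reported in this assay, so its own standing cannot be read from the data; the only guide is that compound 2, which carries a different group at the same place, sits well below compound 1.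

The next compound, compound 4, is `CC1=C(/C=C/C(=O)/C=C/c2cccc([N+](=O)[O-])c2)C(C)(C)CCC1O`. Compared with compound 3 the change is nitro in place of cyano on an aromatic carbon. Within the data shown here, no measured step bears directly on a swap of cyano for nitro, and the step from compound 1 to compound 2 concerns a different group, so it says nothing certain about this exchange. It is therefore expected that compound 4 will land in the same broad region as compound 2 rather than near compound 1, with a wide margin on either side. The estimate for compound 4 in this assay is 3000 nM, expected to lie between 700 nM and 13000 nM.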

Compound 4, half-maximal inhibitory concentration: 6000 nM
For compound 4 the middle estimate is 2.0-fold (0.30 log units) below the measured one, and the stated range covers the measured number.
By their numbers in this assay, from the lowest: compound 2; then compound 4; then compound 1.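

In this assay nitro in place of hydrogen gives a 2.1-fold lower number from compound 1 to compound 4 (0.32 log units; beyond the scatter) and so shows that the drop at this place on the outer aromatic ring is not tied to trifluoromethyl alone, since both groups with a number here lower it. The two groups are not interchangeable, however: nitro in place of trifluoromethyl gives a 2.3-fold higher number from compound 2 to compound 4 (0.36 log units; beyond the scatter) and this means that the identity of the group, and not just the presence of one, changes the result. No measurement available here explains why these two groups differ.

Going by these compounds, compound 3 has no reported number, so the exchange of cyano for nitro cannot be read, and it remains unknown whether cyano would also lower the number compared with hydrogen. Also open, on these data alone, is how an amine, a carboxylic acid or a longer chain would compare at this same place, and whether trifluoromethyl and nitro would keep their order on a different carbon of the ring.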